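A few compounds are considered here, and "the series" means these few. Any claim that something is new, unique, unknown or untested is made for them only; others in the source may bear on it.

Compound 1, `CN(C)CCN(CCN(C)C)c1cccc(C(=O)N2CCc3ccc(OS(N)(=O)=O)cc3C2)c1`, gives 0% in an assay on HEK293 cells for inhibition of Steryl-sulfatase (Homo sapiens), tested at 0.1 uM; a higher number here means a stronger effect of the compound at the concentration tested, a lower number a weaker effect.
Compound 2, `CCN(Cc1ccccn1)c1ccc(C(=O)N2CCc3ccc(OS(N)(=O)=O)cc3C2)cc1`, gives 42.5% in this assay.
Compound 3, `CCN(Cc1ccc(F)cc1)c1ccc(C(=O)N2CCc3ccc(OS(N)(=O)=O)cc3C2)cc1`, gives 69.1% in this assay.

Among these three, compound 1 stands lowest: compound 2 lies beyond the scatter above it, and compound 3 lies further above still. Within the data shown here, the one step measured in one place, a number 26.6 percentage points higher from compound 2 to compound 3 (beyond the scatter), concerns the group on the amine side of the shared core and shows that a change there moves the read-out by a modest amount.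

Compound 4, `NS(=O)(=O)Oc1ccc2c(c1)CN(C(=O)c1cccc(N3CCCCC3)c1)CC2`, differs from compound 1 by piperidin-1-yl in place of bis(2-(dimethylamino)ethyl)amino on an aromatic carbon. Among the measured compounds shown here, no measured step covers this exchange, so the expectation rests on the wider picture: compound 1 with its long, branched amine group gives 0%, while compounds bearing a more compact tertiary amine on the shared core, compound 2 with 42.5% and compound 3 with 69.1%, reach clearly higher read-outs. A rise is therefore expected, but its size is uncertain. Compound 4 is estimated at 35%, within a range of 5% to 70%, which means an expected step of a number 35 percentage points higher from compound 1 to compound 4 (beyond the scatter).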

Compound 4, a percentage reported as inhibition, at one concentration (the size of the read-out at that concentration, not a potency): 1%
For compound 4 the middle estimate is 34 percentage points above the measured one, and the stated range ends above it.
By their numbers in this assay, from the lowest: compounds 1 and 4 (each within the scatter of the next); then compound 2; then compound 3.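

Replacing bis(2-(dimethylamino)ethyl)amino, with 11 heavy atoms and no ring, by piperidin-1-yl, with 6 heavy atoms and one six-membered non-aromatic ring, gives in this assay a number 1 percentage points higher from compound 1 to compound 4 (within the scatter). On this aromatic carbon, meta to a large group, a much smaller ring amine therefore cannot be told apart from the larger open-chain amine, and both read-outs stay close to nothing at the concentration tested. Nothing among the data shown explains why these two groups read alike.

Still open, going by these compounds, is whether any group on this aromatic carbon can raise the read-out on this core, for example a morpholine ring, a primary amine or a carboxylic acid. On these data alone, it is also open whether a shorter amine, such as dimethylamino, would read like these two.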